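A few compounds are considered here, and "the series" means these few. Any claim that something is new, unique, unknown or untested is made for them only; others in the source may bear on it.

Of the compounds shown here, three have been measured in a functional assay on MDA-MB-231 cells (Homo sapiens) for inhibition, read by MTT assay, with a stated time of 72 h, tested at 20 uM; on this read-out lower numbers stand for less inhibition and higher numbers for more inhibition at the one concentration tested (going by the name of the read-out). Compound 1 `CN(c1ccc(Oc2ncnc3ccsc23)cc1)c1nccc(N2CCc3ccccc3C2)n1` gives 30.2% in this assay. Compound 2 `CN(c1ccc(Oc2ncnc3sccc23)cc1)c1nccc(N2CCCC2)n1` gives 31% in this assay, and its number differs from that of compound 1 only within the scatter, so the two cannot be told apart. Compound 3 `c1ccc2c(c1)CCN(c1ccnc(Nc3ccc(Oc4ncnc5ccsc45)cc3)n1)C2` gives 15.4% in this assay. Compound 3 is compound 1 with one change, namely (hydrogen in place of methyl on a nitrogen on an aromatic ring); this change made a step of a number 14.8 percentage points lower from compound 1 to compound 3 (beyond the scatter).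

Compound 4 `c1cc(N2CCCC2)nc(Nc2ccc(Oc3ncnc4sccc34)cc2)n1` has not yet been measured in this assay. It is compound 2 with the same change, namely (hydrogen in place of methyl on a nitrogen on an aromatic ring). The place of the change is described in the same words for both pairs, so the change is the same, not merely the same kind. How the core of compound 2 differs from the core of compound 1 is not broken down here. Compound 1 gives 30.2% and compound 2 gives 31%, and these two numbers lie within the scatter of each other. Because the change from compound 1 to compound 3 made a step of a number 14.8 percentage points lower from compound 1 to compound 3 (beyond the scatter), a step of about the same size is expected for compound 4, namely a number 15 percentage points lower from compound 2 to compound 4 (beyond the scatter), with the caution that this rests on a single earlier instance. Compound 4 is therefore expected to give about 16% in this assay, estimated to lie between 5% and 27%.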

Compound 4, a percentage reported as inhibition, at one concentration (the size of the read-out at that concentration, not a potency): 24.7%
Compound 4: middle estimate off by 8.7 percentage points, on the low side; the measured number falls inside the stated range.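

In this assay, putting hydrogen in place of methyl on a nitrogen on an aromatic ring gave a number 6.3 percentage points lower from compound 2 to compound 4 (within the scatter), so on this core the change cannot be told apart from no change at all, whereas on the core of compound 1 it gave a number 14.8 percentage points lower from compound 1 to compound 3 (beyond the scatter). Even so, the two steps cannot be said to differ, so the result does not show that the change behaves differently on the two cores: the same change on two cores in this assay, a number 14.8 percentage points lower (beyond the scatter) from compound 1 to compound 3 and a number 6.3 percentage points lower (within the scatter) from compound 2 to compound 4, 8.5 percentage points apart, within the scatter of two such steps This shows that the step seen on one core is compatible with the step seen on the other, but with only two pairs it does not fix the size of the step, and it does not show that the change would carry over in the same way to any further core in this series.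

Every compound shown carries either methyl or hydrogen on that nitrogen, so it remains open what an ethyl group, a longer chain or an acetyl group in the same place would do. Each number is also a reading at a single concentration, which leaves open how the potencies of these compounds compare.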